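The compounds below may be only part of what the source reports. "The series", "measured", "known", "first", "only" and "open" are said of these compounds alone.

Working notes on the series. Going by the values given here, in an assay for positive allosteric modulation of metabotropic glutamate receptor 3 (Rattus norvegicus) (on this read-out lower numbers stand for an effect already at smaller amounts and higher numbers for an effect only at larger amounts of compound), compound 2 `Cc1c(OC[C@@H](C)COc2ccc(C(=O)O)c(F)c2)ccc(C(=O)CC(C)(C)C)c1O` gives 1090 nM, the lowest of the two numbers measured so far; compound 1 `Cc1c(OC[C@@H](C)COc2cc(C(=O)O)ccc2F)ccc(C(=O)CC(C)(C)C)c1O` gives 3950 nM. Among the compounds with values here, the one measured step, a 3.6-fold lower number from compound 1 to compound 2 (0.56 log units; beyond the scatter), moved the carboxy and fluorine around the ring on the oxygen on a saturated carbon and left the carboxy in place. Compound 3 `COc1cccc(OC[C@H](C)COc2ccc(C(=O)CC(C)(C)C)c(O)c2C)c1` differs from compound 2 as follows: 3-methoxyphenyl in place of 4-carboxy-3-fluorophenyl on an oxygen on a saturated carbon. Within the data shown here, no measured step bears on removing the carboxylic acid, the 1 hydrogen-bond donor, and the fluorine together; the step from compound 1 to compound 2 only shows that this assay responds to changes on this ring by a modest amount. The expected step is therefore uncertain and leans toward a higher number, a 2.8-fold higher number from compound 2 to compound 3 (0.44 log units; beyond the scatter). Compound 3 is estimated at 3000 nM, within a range from 700 nM to 13000 nM.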

Compound 3, half-maximal effective concentration: "not active" (no number reported)
The entry for compound 3 holds no number; no gap can be computed for the estimate.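

Going by these compounds alone, compound 3 carries the entry "not active" and no number, so no step from compound 2 to compound 3 can be read. The compounds shown leave open whether the carboxy group, the fluorine or both matter on this ring, and nothing shown accounts for this result.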